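The compounds below may be only part of what the source reports. "The series", "measured", "known", "first", "only" and "open" are said of these compounds alone.

Of the compounds shown here, three built on a shared core have been measured in a physicochemical assay for lipophilicity, read by HPLC, at pH 7.5; on this read-out higher numbers stand for higher lipophilicity and lower numbers for lower lipophilicity. Compound 1 `N#Cc1c(-c2ccc(Br)cc2)nc2cnccc2c1NCC(N)=O` gives 1.9, compound 3 `CC(C)(CC(N)=O)c1c(C#N)c(-c2ccc(Br)cc2)nc2cnccc12` gives 2.1, and compound 2 `CC[C@@H](Nc1c(C#N)c(-c2ccc(-c3cccc(C)c3)cc2)nc2cnccc12)C(N)=O` gives 3. Compound 2 stands highest of the three, beyond the scatter from each of the other two, while compound 1 and compound 3 lie within the scatter of one another. For the measured compounds named here, the only measured step between close neighbours is a number 0.20 log units higher from compound 1 to compound 3 (within the scatter), and it concerns a different group at a different place on the core.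

Compound 4 `CC[C@@H](Nc1c(C#N)c(-c2ccc(-c3ccc(Cl)cc3)cc2)nc2cnccc12)C(N)=O` differs from compound 2 in one place: 4-chlorophenyl in place of 3-methylphenyl on an aromatic carbon. Going by the values given here, no measured step covers an exchange of this kind, so the expectation rests on the change being a swap of one small ring substituent for another of equal size, with no donors or acceptors leaving or entering. In this assay compound 4 is therefore expected to move by a number 0.10 log units higher from compound 2 to compound 4 (within the scatter), a step not beyond the scatter. Compound 4 is estimated at 3.1, with a range from 2.7 to 3.5.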

Compound 4, distribution coefficient: 3.1
Compound 4: middle estimate and measured number agree at the digits printed, within the range that was stated.
By their numbers in this assay, from the lowest: compounds 1 and 3 (each within the scatter of the next); then compounds 2 and 4 (each within the scatter of the next).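

In this assay, for the compounds shown here, exchanging 3-methylphenyl for 4-chlorophenyl gives a number 0.10 log units higher from compound 2 to compound 4 (within the scatter), the first measured step at this place on the shared core. Both groups have the same count of heavy atoms, a six-membered aromatic ring of carbon only, and no hydrogen-bond donors or acceptors, and this read-out does not separate compound 2 from compound 4. No experimental evidence bears on why this exchange leaves the two numbers within the scatter.

This single exchange alters both the ring substituent and where it sits, so 3-chlorophenyl or 4-methylphenyl would be needed to tell those two changes apart. From the compounds shown here alone, it also remains open whether a more different group here, such as a phenyl ring carrying an amine or a carboxylic acid, would give a step beyond the scatter.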